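Ethyl Ester in Place of Acid, Tried on a Second Core

A few compounds are considered here, and "the series" means these few. Any claim that something is new, unique, unknown or untested is made for them only; others in the source may bear on it.

Compound 1, `CCOc1ccc([N+](=O)[O-])cc1-c1ncc(C(=O)O)c(=O)[nH]1`: 25 mg/kg
Compound 2, `CCOC(=O)c1cnc(-c2cc([N+](=O)[O-])ccc2OCC)[nH]c1=O`: 5 mg/kg
Compound 3, `COc1nc(-c2ccccc2)ncc1C(=O)O`: > 10 mg/kg

All three were tested in a functional assay on the whole organism (strain Sprague-Dawley) for inhibition, with Rattus norvegicus as the target, with a stated time of 10 min; on this read-out higher numbers stand for an effect only at larger amounts of compound and lower numbers for an effect already at smaller amounts. Compound 2 differs from compound 1 by ethyl in place of hydrogen on an oxygen next to a carbonyl group, and this change gave a 5.0-fold lower number from compound 1 to compound 2 (0.70 log units; beyond the scatter). For compound 3 the value is a limit of this assay, not a number, the compound being one of those at the limit of > 10 mg/kg in this assay, at which 1 of the 3 values shown sits. How the core of compound 3 differs from the core of compound 1 is not broken down here.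

Compound 4, `CCOC(=O)c1cnc(-c2ccccc2)nc1OC`, is not yet measured. Among the compounds with values here, it differs from compound 3 by ethyl in place of hydrogen on an oxygen next to a carbonyl group, the same change as the one from compound 1 to compound 2, made at the same place. The step from compound 3 to compound 4 in this assay is expected to be an at least 1.6-fold lower number from compound 3 to compound 4 (0.22 log units; that floor lies within the scatter), an expectation that rests on the step of a 5.0-fold lower number from compound 1 to compound 2 (0.70 log units; beyond the scatter) seen on the other core. Since compound 3 has only a limit, the starting point is uncertain, and the range is kept wide. Compound 4 is therefore estimated at 6 mg/kg, between 2 mg/kg and 20 mg/kg.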

Compound 4, dose for 50% inhibition: > 5 mg/kg
Compound 4: a limit, no number (the forecaster's own chance of this, stated with the estimate: 35%); the middle value lies beyond the limit too.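

In this assay compound 3 gives > 10 mg/kg, which is a limit and not a number. Compound 4 gives > 5 mg/kg, also a limit, and no step can be read from compound 3 to compound 4. The compounds shown leave open whether ethoxycarbonyl in place of carboxy changes the dose on the core of compound 3 at all, and in which direction.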